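The compounds below may be only part of what the source reports. "The series", "measured", "known", "first", "only" and "open" are said of these compounds alone.

A small set of compounds shares one core and differs only in the group on a sulfonamide nitrogen. In a functional assay on HT-29 cells (Homo sapiens) for antiproliferative activity, read by sulforhodamine B assay, with a stated time of 48 h (on this read-out higher numbers stand for weaker inhibition and lower numbers for stronger inhibition), compound 1 `Cc1cccc(NS(=O)(=O)c2ccc(N3CCNC3=O)cc2)c1` gives 110 nM, compound 2 `O=C1NCCN1c1ccc(S(=O)(=O)Nc2ccc(Cl)cc2)cc1` gives 220 nM and compound 3 `Cc1ccccc1NS(=O)(=O)c1ccc(N2CCNC2=O)cc1` gives 200 nM. Compound 3 therefore sits inside a tight cluster, within the scatter of both other compounds, and cannot be ranked against them.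

Compound 4 `COc1cccc(NS(=O)(=O)c2ccc(N3CCNC3=O)cc2)c1` has not yet been measured. It carries 3-methoxyphenyl in place of the 2-methylphenyl of compound 3 on a sulfonamide nitrogen: 3-methoxyphenyl in place of 2-methylphenyl on a sulfonamide nitrogen.

Among the measured compounds shown here, no measured compound here carries a methoxy group, so the evidence is indirect. For the measured compounds named here, three measured steps bear on the change: a 1.8-fold higher number from compound 1 to compound 3 (0.26 log units; within the scatter), a 1.1-fold lower number from compound 2 to compound 3 (0.04 log units; within the scatter) and a 2.0-fold higher number from compound 1 to compound 2 (0.30 log units; within the scatter). Each swap of this group has stayed within the scatter, so a step beyond the scatter is not expected. Compound 1 carries 3-methylphenyl, the measured group whose name comes closest to 3-methoxyphenyl, and its value of 110 nM pulls the expectation slightly toward lower numbers. The estimated step is a 1.4-fold lower number from compound 3 to compound 4 (0.15 log units; within the scatter), which is expected to stay within the scatter. For compound 4 the estimated value is 140 nM, with an expected range from 60 nM to 320 nM.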

Compound 4, half-maximal inhibitory concentration: 120 nM
Compound 4: middle estimate off by 1.2-fold (0.07 log units), on the high side, and the stated range covers the measured number.
By their numbers in this assay, from the lowest: compounds 1, 4, 3 and 2 (each within the scatter of the next).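

In this assay, among the compounds shown here, compound 4 brings to this position the first group with an oxygen atom, counted as a hydrogen-bond acceptor, and this still opens no gap beyond the scatter against any earlier compound (a 1.7-fold lower number from compound 3 to compound 4 (0.22 log units; within the scatter)) (a 1.8-fold lower number from compound 2 to compound 4 (0.26 log units; within the scatter)). For the compounds shown here, the closest comparison is the single swap of methoxy in place of methyl on an aromatic carbon (a 1.1-fold higher number from compound 1 to compound 4 (0.04 log units; within the scatter)): it is the smallest of the new steps and lies within the scatter, so on this read-out the two groups cannot be told apart, and the position has now accepted four different substituted phenyl groups with no separation among them. No measurement here offers an explanation for this tolerance.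

All four groups are neutral phenyl rings carrying one small substituent, so the compounds shown only sample a narrow range of what this position might hold. On these data alone, it stays open whether a larger or charged group, such as a longer ethoxy chain, an amine or a carboxylic acid on the ring, or a pyridine ring in place of the phenyl, would produce a step beyond the scatter.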